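A few compounds are considered here, and "the series" means these few. Any claim that something is new, unique, unknown or untested is made for them only; others in the source may bear on it.

Compound 1 `NNC(=O)CCc1ccncc1-c1ccc2ccccc2c1` and compound 2 `O=C(CCc1ccncc1-c1ccc2ccccc2c1)N1CCOCC1` share one core and differ only in the group on a carbonyl carbon. In a functional assay on HCT-116 cells (Homo sapiens) for inhibition, read by MTT assay, with a stated time of 72 h (on this read-out higher numbers stand for weaker inhibition of growth and lower numbers for stronger inhibition of growth), compound 1 gives > 30000 nM, which is a limit of the assay and not a number. In this assay compound 2 gives > 30000 nM, and this is also a limit. Compound 2 therefore has no exact value and stands at the limit of > 30000 nM in this assay, at which 2 of the 2 values shown sit.

The next compound is compound 3 `CNC(=O)CCc1ccncc1-c1ccc2ccccc2c1`, with the change methylamino in place of morpholin-4-yl on a carbonyl carbon. Among the measured compounds shown here, the one measured step that bears on this is a step that the two limits leave unreadable from compound 1 to compound 2, which also exchanges the group at that place. For the measured compounds named here, it offers no size to carry over, and no measured step here points in either direction. No change beyond the usual scatter can therefore be predicted, and a further limit is the likeliest report. The expected step is a number no higher from compound 2 to compound 3 (the limit leaves the size open). The estimate for compound 3 is 30000 nM, with an expected range from 12000 nM to 60000 nM.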

Compound 3, concentration for 50% growth inhibition: 19300 nM
Estimate against measurement, compound 3: 1.6-fold (0.19 log units) above; low and high end bracket the measured number.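

In this assay compound 3 is the first of these compounds to give an exact number rather than a limit, so this place on a carbonyl carbon now has one real reading. Replacing morpholin-4-yl with methylamino removes the ring and adds a hydrogen-bond donor, and it gives an at least 1.5-fold lower number from compound 2 to compound 3 (0.19 log units; that floor lies within the scatter) while methyl in place of amino on an amide-type nitrogen gives an at least 1.5-fold lower number from compound 1 to compound 3 (0.19 log units; that floor lies within the scatter) in the same assay. Both steps are only floors that do not clear the usual scatter, so neither change is shown to give a real gain in growth inhibition, and their true size stays unknown, as the other two compounds remain at a limit: the limit of > 30000 nM in this assay, at which 2 of the 3 values shown sit.

From the compounds shown here alone, it remains open whether ethylamino or dimethylamino on the same carbonyl carbon, or a carboxylic acid in place of the amide, would move the number beyond the scatter. Going by these compounds, it is equally open whether a longer saturated chain on that carbonyl carbon would change the reading in this assay at all.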